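The source may hold more compounds than are shown below. What is called first, only, known or untested is meant among the compounds shown, and "the series" means these compounds.

Measured so far:
compound 1 `Cc1ccccc1-n1cc(-c2ccc(NS(=O)(=O)c3c[nH]c(=O)[nH]c3=O)cc2)nn1` — 3130 nM
compound 2 `O=c1[nH]cc(S(=O)(=O)Nc2ccc(-c3cn(-c4ccc(F)cc4)nn3)cc2)c(=O)[nH]1` — 9720 nM

In a functional assay on A549 cells (Homo sapiens) for antiproliferative activity, read by MTT assay, with a stated time of 24 h (a higher number here means a weaker inhibitor, a lower number a stronger inhibitor), compound 2 gives 9720 nM, the higher of the two numbers; compound 1 gives 3130 nM, the two separated by a 3.1-fold higher number from compound 1 to compound 2 (0.49 log units; beyond the scatter). Compound 3 `O=c1[nH]cc(S(=O)(=O)Nc2ccc(-c3cn(-c4ccc(Cl)cc4)nn3)cc2)c(=O)[nH]1` differs from compound 2 by chloro in place of fluoro on an aromatic carbon. For the measured compounds named here, no measured step exchanges one halogen for another; the single step known, a 3.1-fold higher number from compound 1 to compound 2 (0.49 log units; beyond the scatter), swaps the whole aryl group and bears only loosely on this change. In this assay a step of about a 1.4-fold lower number from compound 2 to compound 3 (0.14 log units; within the scatter) is therefore expected, not beyond the scatter. Compound 3 is estimated at 7000 nM, range 2500 nM to 20000 nM.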

Compound 3, half-maximal inhibitory concentration: 1210 nM
The estimate for compound 3 lay 5.8-fold (0.76 log units) above the measured number; measured number below the stated range.
By their numbers in this assay, from the lowest: compound 3; then compound 1; then compound 2.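

In this assay, exchanging one halogen for another at this position is not a neutral change: chloro in place of fluoro gives an 8.0-fold lower number from compound 2 to compound 3 (0.90 log units; beyond the scatter). The 4-chlorophenyl group also outperforms 2-methylphenyl, with a 2.6-fold lower number from compound 1 to compound 3 (0.41 log units; beyond the scatter), so the earlier advantage of 2-methylphenyl over 4-fluorophenyl does not extend to every group with a substituent para to the large group. No available evidence bears on the reason for this halogen difference.

Still open, on these data alone, is whether bromo, methyl or methoxy at this position would follow chloro or fluoro. As far as these compounds go, an amine or a carboxylic acid there also remains untested in these data.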